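Chlorofuran to chlorophenyl on the acrylamide arm

The compounds below may be only part of what the source reports. "The series", "measured", "known", "first", "only" and "open" are said of these compounds alone.

Compound 2 `COc1ccc(CNC(=O)/C(C#N)=C/c2ccc(Cl)o2)cc1` gives 13000 nM in a functional assay on SJ-G2 cells (Homo sapiens) for inhibition, read by MTT assay, with a stated time of 72 h (a lower number here means a stronger inhibitor of growth, a higher number a weaker inhibitor of growth), the lowest of the two numbers shown, and compound 1 `N#C/C(=C\c1ccc([N+](=O)[O-])cc1)C(=O)c1c[nH]c2ccccc12` gives 37000 nM in this assay. Compound 3 `COc1ccc(CNC(=O)/C(C#N)=C/c2ccc(-c3ccccc3)o2)cc1` reaches only the limit > 100000 nM in this assay. For the measured compounds named here, the single measured step, an at least 7.6-fold higher number from compound 2 to compound 3 (0.88 log units; beyond the scatter), exchanges a substituent on the furan and is bounded by the limit of > 100000 nM in this assay, at which 1 of the 3 values shown sits. Compound 4 `COc1ccc(CNC(=O)/C(C#N)=C/c2ccc(Cl)cc2)cc1` carries 4-chlorophenyl in place of 5-chlorofuran-2-yl on a double-bonded chain carbon bound to a double-bonded chain carbon. Going by the values given here, no measured step covers this ring exchange; the step from compound 2 to compound 3 is the only reference and does not share the change. A modest loss is therefore expected, as a 1.9-fold higher number from compound 2 to compound 4 (0.28 log units; within the scatter). Compound 4 is estimated at 25000 nM in this assay, within 6000 nM to 100000 nM.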

Compound 4, concentration for 50% growth inhibition: 11000 nM
The estimate for compound 4 lay 2.3-fold (0.36 log units) above the measured number, and the stated range covers the measured number.
By their numbers in this assay, from the lowest: compounds 4 and 2 (each within the scatter of the next); then compound 1. At a limit, above all of these: compound 3.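

In this assay the ring exchange gives a 1.2-fold lower number from compound 2 to compound 4 (0.07 log units; within the scatter), so compound 2 and compound 4 cannot be told apart. At this position, 4-chlorophenyl can thus stand in for 5-chlorofuran-2-yl without a change beyond the scatter, something the step on the furan substituent could not show. No measurement shown bears on a cause for this ring exchange.

Still open, going by these compounds, is how compound 4 would read with an amine or a carboxylic acid in place of its chloro group. Also open, on these data alone, is whether a pyridine ring would match either ring.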